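A Small Added Methyl at the Assay Limit

A few compounds are considered here, and "the series" means these few. Any claim that something is new, unique, unknown or untested is made for them only; others in the source may bear on it.

In an ADME assay on HEK293 cells (Homo sapiens) for cytotoxicity, with a stated time of 72 h (a lower number here means that less compound is needed, a higher number that more compound is needed for the effect), compound 2 (`CCOC(=O)/C=C/c1cc(/C=C/[C@](C)(/C=C/c2ccc(OC)cc2)CCC=C(C)C)ccc1O`) gives > 36600 nM as a limit, not a number, and stands at the limit of > 36600 nM in this assay, at which 2 of the 2 values shown sit, among the data so far. Compound 3 (`CCOC(=O)/C(C)=C/c1cc(/C=C/[C@](C)(/C=C/c2ccc(OC)cc2)CCC=C(C)C)ccc1O`) has 2-(ethoxycarbonyl)prop-1-en-1-yl in place of 2-(ethoxycarbonyl)ethenyl on an aromatic carbon. Compound 1 (`C=C[C@@](C)(/C=C/c1ccc(O)c(/C=C(\C)C(=O)OCC)c1)CCC=C(C)C`) already carries 2-(ethoxycarbonyl)prop-1-en-1-yl and gives > 36600 nM as a limit too. The estimated step of a number no higher from compound 2 to compound 3 (the limit leaves the size open) is expected to stay within the usual scatter of this assay with no clear direction. Compound 3 is estimated at 36600 nM within an expected range of 18000 nM to 50000 nM as its upper end.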

Compound 3, half-maximal effective concentration: > 36600 nM
Compound 3: only a limit was reported; the forecaster's own chance of this, stated with the estimate: 80%; the middle value sits exactly at the limit.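

No step can be read between compound 1, compound 2 and compound 3, because each gives only a limit, not a number: the limit of > 36600 nM in this assay, at which 3 of the 3 values shown sit. The compounds shown leave open how much of each is needed for the effect, and whether either change alters it.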